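The compounds below may be only part of what the source reports. "The series", "measured", "known", "first", "only" and "open" are said of these compounds alone.

Both measured compounds were tested in an assay on Sf9 cells for inhibition of serine/threonine-protein kinase 4 (Homo sapiens), read by luminescence and ADP-Glo, with a stated time of 1 h, in the presence of a further agent that is not named here; a higher number here means a weaker inhibitor, a lower number a stronger inhibitor:

compound 1, `CN1C(=O)C(c2cccc(C(F)(F)F)c2)N(C)c2nc(Nc3ccc(S(N)(=O)=O)cc3)ncc21`, gives 2710 nM
compound 2, `Cc1c(F)cccc1C1C(=O)N(C)c2cnc(Nc3ccc(S(N)(=O)=O)cc3)nc2N1C`, gives 419 nM

Among the measured compounds shown here, compound 2 stands at the lower of the two numbers, and the only step measured here, a 6.5-fold lower number from compound 1 to compound 2 (0.81 log units; beyond the scatter), lies beyond the scatter. That single step is also the only one touching the same saturated ring carbon where compound 3 differs.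

Compound 3, `CN1C(=O)C(Cc2ccccc2)N(C)c2nc(Nc3ccc(S(N)(=O)=O)cc3)ncc21`, differs from compound 2 in one place: benzyl in place of 3-fluoro-2-methylphenyl on a saturated ring carbon. The measured step exchanged one aromatic ring for another one bearing different substituents and moved the number by a modest amount. The change to compound 3 is of a different kind, since the aromatic ring no longer sits directly on the ring carbon but is carried on a benzyl group, and nothing measured here covers such a change. For the measured compounds named here, what the one step shows is that the group on this carbon can shift the number beyond the scatter in either direction.

With no closer comparison, compound 3 is expected to land somewhat weaker than compound 2, a step of a 2.9-fold higher number from compound 2 to compound 3 (0.46 log units; beyond the scatter), with a wide range. The estimate for compound 3 in this assay is 1200 nM, between 300 nM and 5000 nM.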

Compound 3, half-maximal inhibitory concentration: > 10000 nM
Compound 3: only a limit was reported (the forecaster's own chance of this, stated with the estimate: 10%); middle value at least 8.3-fold (0.92 log units) from the limit.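

In this assay compound 3 gives only a limit rather than a number: the limit of > 10000 nM in this assay, at which 1 of the 3 values shown sits.

Even read as a limit, the change is large: benzyl in place of 3-fluoro-2-methylphenyl gives an at least 23-fold higher number from compound 2 to compound 3 (1.37 log units; beyond the scatter), and benzyl in place of 3-(trifluoromethyl)phenyl gives an at least 3.6-fold higher number from compound 1 to compound 3 (0.56 log units; beyond the scatter). Both steps lie beyond the scatter, so the benzyl compound is weaker than either compound with its aromatic ring sitting directly on the saturated ring carbon, a far larger effect at this position than the earlier exchange of one such ring for another suggested. The entering and leaving groups each hold one six-membered aromatic ring of carbon only and no hydrogen-bond donors or acceptors, so a modest-looking edit on paper can still cost much of the measured inhibition here.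

Benzyl differs from both earlier groups in two ways at once, as its ring is carried on an extra carbon and has no substituents, and an unsubstituted phenyl on the same carbon would be needed to tell these apart. Also open, going by these compounds, is how a longer chain such as 2-phenylethyl, or an amine on this carbon, would read in this assay.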